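Series notes: two measured compounds, one pending

A few compounds are considered here, and "the series" means these few. Any claim that something is new, unique, unknown or untested is made for them only; others in the source may bear on it.

Measured so far:
compound 1, `Nc1scc(CN2CCN(c3cccc(C(F)(F)F)c3)CC2)c1C(=O)c1ccc(Cl)cc1`: -8.2%
compound 2, `Nc1scc(CN2CCN(c3cccc(F)c3)CC2)c1C(=O)c1cccc(C(F)(F)F)c1`: -11%

In a functional assay on CHO cells with adenosine receptor A1 (Homo sapiens) as the target, read by cAMP accumulation and immunoassay, with a stated time of 6 min, tested at 0.01 uM (on this read-out lower numbers stand for a stronger effect and higher numbers for a weaker effect at the one concentration tested), compound 1 gives -8.2%, the higher of the two numbers; compound 2 gives -11%, and the gap between them lies within the scatter, so the two are not separable. Compound 3 `Nc1scc(CN2CCN(c3ccc(F)cc3F)CC2)c1C(=O)c1ccc(Cl)cc1` is not yet measured. It differs from compound 1 by 2,4-difluorophenyl in place of 3-(trifluoromethyl)phenyl on an amine nitrogen in a ring. Within the data shown here, no step between measured compounds is available to size this change, so in this assay nothing beyond the scatter is expected. Compound 3 is expected to give about -8% in this assay, between -25% and 10%. The expected step of a number 0.2 percentage points higher from compound 1 to compound 3 (within the scatter) is none beyond the scatter.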

Compound 3, a percentage reported as activity, at one concentration (the size of the read-out at that concentration, not a potency): 0%
Compound 3: middle estimate off by 8 percentage points, on the low side; the measured number falls inside the stated range.
By their numbers in this assay, from the lowest: compounds 2, 1 and 3 (each within the scatter of the next, the first and the last beyond it).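

In this assay, among these compounds, the swap from 3-(trifluoromethyl)phenyl to 2,4-difluorophenyl on the amine nitrogen in a ring gives a number 8.2 percentage points higher from compound 1 to compound 3 (within the scatter) and is the first step sized at this place. On this pair, the two aryl groups cannot be told apart at the one concentration tested. No measured evidence bears on this result.

From the compounds shown here alone, whether the same swap reads alike with a different group on the carbonyl stays open. Also open, going by these compounds, is whether a pyridine ring, a benzyl group or a carboxylic acid on the aryl ring would move the number beyond the scatter.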